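Ring replacement at the chain terminus: what to expect of compound 4

This account rests on a few compounds, and the source may have more. Where it says the series, first, only, none or still open, it means among the compounds named here.

Measured so far in an assay on RPMI-8226 cells for antagonist activity at P2X purinoceptor 7 (Homo sapiens), read by calcium flux; on this read-out lower numbers stand for stronger inhibition and higher numbers for weaker inhibition:
compound 1 `O=c1[nH]c2ccccc2n1CCCCN1CCN(C(c2ccccc2)c2ccccc2)CC1` gives 180 nM
compound 2 `O=c1[nH]c2ccccc2n1CCCCCN1CCN(C(c2ccccc2)c2ccccc2)CC1` gives 560 nM
compound 3 `COc1ccc2c(ccn2CCCCN2CCN(C(c3ccccc3)c3ccccc3)CC2)c1` gives only a limit of the assay, > 10000 nM

Compound 1 stands lowest of the two numbers shown in this assay; its nearest neighbour is compound 2, and the step of a 3.1-fold higher number from compound 1 to compound 2 (0.49 log units; beyond the scatter) is modest. The step of an at least 55-fold higher number from compound 1 to compound 3 (1.74 log units; beyond the scatter) is large and ends at a limit, (the limit of > 10000 nM in this assay, at which 1 of the 3 values shown sits).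

Compound 4 `Fc1ccc2c(ccn2CCCCN2CCN(C(c3ccccc3)c3ccccc3)CC2)c1` differs from compound 1 by a group of 10 heavy atoms (8 carbon, 1 nitrogen, 1 fluorine; one five-membered aromatic ring with 1 hetero atom, one six-membered aromatic ring of carbon only) in place of a group of 10 heavy atoms (7 carbon, 2 nitrogen, 1 oxygen; one five-membered aromatic ring with 2 hetero atoms, one six-membered aromatic ring of carbon only), on a saturated chain carbon, four bonds along the chain from an amine nitrogen in a ring, the 5-fluoro-1H-indol-1-yl group entering. The step that bears on it is an at least 55-fold higher number from compound 1 to compound 3 (1.74 log units; beyond the scatter), where the same kind of two-heteroatom ring gave way to a one-heteroatom ring and the number rose beyond the scatter to the limit. A large rise in this assay is therefore expected for compound 4, of about a 44-fold higher number from compound 1 to compound 4 (1.65 log units; beyond the scatter). Compound 4 is estimated at 8000 nM, with a range of 2000 nM to 30000 nM, and a fair chance that only a limit is reported.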

Compound 4, half-maximal inhibitory concentration: 120 nM
Beside the measured number, compound 4's estimate is 67-fold (1.82 log units) above it; measured number below the stated range.
By their numbers in this assay, from the lowest: compounds 4 and 1 (each within the scatter of the next); then compound 2. At a limit, above all of these: compound 3.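

In this assay, a five-membered aromatic ring with 1 hetero atom is compatible with activity at this place, on a saturated chain carbon, four bonds along the chain from an amine nitrogen in a ring: with 0 hydrogen-bond donors in the entering group against 1 in the group leaving, the step is a 1.5-fold lower number from compound 1 to compound 4 (0.18 log units; within the scatter), and a 4.7-fold lower number from compound 2 to compound 4 (0.67 log units; beyond the scatter) is the step from the longer-chain compound. The substituent on the aromatic carbon now carries the large difference, with fluoro in place of methoxy giving an at least 83-fold lower number from compound 3 to compound 4 (1.92 log units; beyond the scatter). Compound 3 stands at a limit, not a number: the limit of > 10000 nM in this assay, at which 1 of the 4 values shown sits.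

Still open, going by these compounds, is how a hydrogen, chloro or nitrile on that aromatic carbon would read. Also open, on these data alone, is whether a longer chain on the 5-fluoro-1H-indol-1-yl group would shift the number as it does on the group of compound 1.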